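Fluoro to trifluoromethoxy in compound 4

This account rests on a few compounds, and the source may have more. Where it says the series, first, only, none or still open, it means among the compounds named here.

Measured so far in a functional assay on HCT-116 cells (Homo sapiens) for antiproliferative activity, read by WST assay, with a stated time of 72 h; a lower number here means a stronger inhibitor of growth, a higher number a weaker inhibitor of growth:
Compound 1 `O=C(NO)c1cnc(N2C[C@@H]3[C@H](C2)[C@H]3NC(=O)c2ccccc2)nc1`: 5100 nM
Compound 2 `O=C(NO)c1cnc(N2C[C@@H]3[C@H](C2)[C@H]3NCC2CCCCC2)nc1`: 160 nM
Compound 3 `O=C(NO)c1cnc(N2C[C@@H]3[C@H](C2)[C@H]3NCc2ccc(F)cc2)nc1`: 380 nM

Compound 3 holds the middle place of the three, at 380 nM. Two steps fix that place: a 2.4-fold higher number from compound 2 to compound 3 (0.38 log units; beyond the scatter), and a 13-fold lower number from compound 1 to compound 3 (1.13 log units; beyond the scatter).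

Compound 4 `O=C(NO)c1cnc(N2C[C@@H]3[C@H](C2)[C@H]3NCc2ccc(OC(F)(F)F)cc2)nc1` differs from it in one group, with trifluoromethoxy in place of fluoro on an aromatic carbon. Among the compounds with values here, no measured step changes this substituent on the aromatic ring. The large steps, a 13-fold lower number from compound 1 to compound 3 (1.13 log units; beyond the scatter) and a 32-fold lower number from compound 1 to compound 2 (1.50 log units; beyond the scatter), both remove the benzoyl group from the amine nitrogen, which is a different kind of change and says little here. The closest guide is the modest step between the two amines, a 2.4-fold higher number from compound 2 to compound 3 (0.38 log units; beyond the scatter), where the amine is kept and only the group on the chain changes. A similarly small change is therefore expected in this assay, possibly within the scatter, with a slight lean to a lower number. The estimate is a 1.5-fold lower number from compound 3 to compound 4 (0.16 log units; within the scatter). For compound 4 the expected value is 260 nM, with an estimated range from 90 nM to 750 nM.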

Compound 4, concentration for 50% growth inhibition: 120 nM
The estimate for compound 4 lay 2.2-fold (0.34 log units) above the measured number; the range from low to high includes it.
By their numbers in this assay, from the lowest: compounds 4 and 2 (each within the scatter of the next); then compound 3; then compound 1.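

In this assay, within the data shown here, the substituent on the aromatic ring turns out to matter, which none of the earlier compounds could show: a 3.2-fold lower number from compound 3 to compound 4 (0.50 log units; beyond the scatter). That step also changes the comparison with the saturated side chain, since compound 3 stood apart from compound 2, whereas compound 4 at 120 nM and compound 2 at 160 nM lie within the scatter of each other, so a benzyl group can match the cyclohexylmethyl group here. No measurement is available that accounts for the difference between fluoro and trifluoromethoxy.

Going by these compounds, with only these two substituents on the ring, it remains open whether a methoxy or a trifluoromethyl group would give a similar value. On these data alone, it is also open whether trifluoromethoxy on the benzoyl ring of compound 1 would shift its number in the same way.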